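The source may report more compounds than this note shows. Statements on the series, on what has been measured and on what is new or still open speak of the compounds shown alone.

Among the measured compounds shown here, only two compounds sharing one core have so far been tested in a functional assay on LNCaP cells (Homo sapiens) for cytotoxicity, read by MTT assay; on this read-out lower numbers stand for stronger inhibition and higher numbers for weaker inhibition. Compound 1 `COc1ccc(CSc2nnc([C@@H](C)c3ccc4cc(OC)ccc4c3)n2-c2ccc(Cl)cc2)cc1` gives <= 400000 nM in this assay, and this value is a limit of the assay, not a number. For the measured compounds named here, compound 2 `COc1ccc2cc([C@H](C)c3nnc(SCc4ccc(F)cc4)n3-c3ccc(F)cc3)ccc2c1` gives 104000 nM, the only actual number available, so its standing cannot be judged against another measured potency.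

Compound 3 `COc1ccc(CSc2nnc([C@@H](C)c3ccc4cc(OC)ccc4c3)n2-c2ccc(F)cc2)cc1` follows from compound 2 through a single change: methoxy in place of fluoro on an aromatic carbon. Methoxy takes the place of fluoro on an aromatic carbon, para to a large group, turning 4-fluorobenzyl into 4-methoxybenzyl.

Going by the values given here, no pair of measured compounds shows what this change does in this assay, so the data offer no size or direction for it. The expectation is therefore for no step beyond the scatter, and it rests on compound 2 at 104000 nM. The estimated change is small, expressed as a 1.1-fold higher number from compound 2 to compound 3 (0.02 log units; within the scatter). Compound 3 is expected at about 110000 nM, with an estimated range from 45000 nM to 300000 nM.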

Compound 3, half-maximal inhibitory concentration: 22800 nM
The estimate for compound 3 lay 4.8-fold (0.68 log units) above the measured number; measured number below the stated range.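

In this assay, methoxy in place of fluoro on an aromatic carbon, para to a large group, turning 4-fluorobenzyl into 4-methoxybenzyl, gives a 4.6-fold lower number from compound 2 to compound 3 (0.66 log units; beyond the scatter). Among the compounds shown here, this is the first step that can be read, and it shows that the group at this place on the benzyl ring can move the number beyond the usual scatter, something the earlier compounds could not show. Compound 1 carries only a limit of the assay, so the other step, fluoro in place of chloro on an aromatic carbon, cannot be read, because it starts from this limit: the limit of <= 400000 nM in this assay, at which 1 of the 3 values shown sits.

Going by these compounds, with a single readable step, it stays open whether the lower number belongs to methoxy as such or would also appear with another group at the same place, such as a hydroxy group, an ethoxy group or an amine, or with plain hydrogen. On these data alone, the 4-fluorophenyl group that compound 2 and compound 3 share also stays open, as no readable step shows what a different group there would do to the number.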